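The compounds below may be only part of what the source reports. "The series", "measured", "known", "first", "only" and "open" are said of these compounds alone.

Compound 2, `COc1cc(F)c(CN2C(=O)N(c3ccc(OC)c(OC)c3)S(=O)(=O)c3ccccc32)c(Cl)c1`, is the stronger of the two compounds measured in an assay on HEK293 cells for displacement of a labelled ligand from Orexin receptor type 2 (Homo sapiens), read by scintillation counting, with a stated time of 90 min (on this read-out lower numbers stand for stronger inhibition and higher numbers for weaker inhibition), where compound 2 gives 0.1 nM. The other measured compound, compound 1, `COc1cc(F)c(CN2C(=O)N(c3cc(OC)nc(OC)c3)S(=O)(=O)c3ccccc32)c(F)c1`, carries a different aryl group on the sulfonylurea nitrogen and a different benzyl group; in this assay compound 1 gives 0.251 nM, a higher number than that of compound 2 by more than the usual scatter. Compound 3, `COc1cc(F)c(CN2C(=O)N(c3ccc(OC)c(OC)c3)S(=O)(=O)c3ccccc32)c(F)c1`, is compound 2 with one alteration: fluoro in place of chloro on an aromatic carbon. For the measured compounds named here, no measured pair in this set isolates that exchange, so there is no directly comparable step to lean on. With compound 2 giving 0.1 nM as the starting point, the step from compound 2 to compound 3 is expected to be small, a 2.0-fold higher number from compound 2 to compound 3 (0.30 log units; within the scatter), probably within the scatter, with a slight lean toward a higher number. Compound 3 is therefore estimated at 0.2 nM in this assay, with a plausible range from 0.08 nM to 0.5 nM.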

Compound 3, inhibition constant: 0.501 nM
Compound 3: middle estimate off by 2.5-fold (0.40 log units), on the low side, outside the stated range (above it).
By their numbers in this assay, from the lowest: compound 2; then compounds 1 and 3 (each within the scatter of the next).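

In this assay, for the compounds shown here, the exchange of chloro for fluoro on this aromatic carbon, ortho to a large group, gives the first direct reading at this position, and the step is a 5.0-fold higher number from compound 2 to compound 3 (0.70 log units; beyond the scatter). Going by these compounds alone, with the 2,6-difluoro-4-methoxybenzyl group held constant, 3,4-dimethoxyphenyl in place of 2,6-dimethoxypyridin-4-yl on the amide-type nitrogen gives a 2.0-fold higher number from compound 1 to compound 3 (0.30 log units; within the scatter), so the change at this carbon is the only one of the two steps that stands clear of the scatter. No measurement shown here accounts for the size of the chloro-to-fluoro step.

The compounds shown do not tell whether this step carries over to compounds with 2,6-dimethoxypyridin-4-yl on the nitrogen. They also leave open how bromo, methyl or a methoxy group at this carbon would compare with chloro.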